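The source may hold more compounds than are shown below. What is called first, only, known or untested is meant among the compounds shown, and "the series" means these compounds.

Compound 1 `CN(C)c1ncnc2c1ncn2Cc1c(F)cccc1F`: 2.2 mg/kg
Compound 2 `CNc1ncnc2c1ncn2Cc1cccc(F)c1F`: 18 mg/kg
Compound 3 `CC(C)Nc1ncnc2c1ncn2Cc1ccccc1F`: 5.8 mg/kg

Of the compounds shown here, three sharing one core have been tested in a functional assay on the whole organism with Rattus norvegicus as the target, in the maximal electroshock model; on this read-out lower numbers stand for an effect already at smaller amounts and higher numbers for an effect only at larger amounts of compound. Compound 3 stands second highest of the three numbers. The nearest to it is compound 1, which gives 2.2 mg/kg, a lower number that lies beyond the scatter of repeated measurements. The furthest is compound 2, which gives 18 mg/kg, a higher number, again beyond the scatter. Compound 3 itself gives 5.8 mg/kg.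

The next compound, compound 4 `CN(C=O)c1ncnc2c1ncn2Cc1ccccc1F`, has not yet been measured in this assay. It differs from compound 3 in one place: formyl(methyl)amino in place of isopropylamino on an aromatic carbon. The group that leaves and the group that enters have the same count of heavy atoms, but the entering group carries no hydrogen-bond donor and contains a double bond outside the aromatic rings.

Among the measured compounds shown here, no step between measured compounds repeats this exact change, so the expectation rests on the spread of the three numbers seen. Compound 4 is expected to stay within that spread, with the step of a 1.4-fold higher number from compound 3 to compound 4 (0.14 log units; within the scatter) estimated to be small and, if anything, toward a higher number. For compound 4 the estimate in this assay is 8 mg/kg, within a range from 3 mg/kg to 22 mg/kg.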

Compound 4, dose for half-maximal effect: 11 mg/kg
Estimate against measurement, compound 4: 1.4-fold (0.14 log units) below; measured number inside the range.
By their numbers in this assay, from the lowest: compound 1; then compounds 3, 4 and 2 (each within the scatter of the next, the first and the last beyond it).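

In this assay, among the compounds shown here, the first measured pair that differs in one place gives a 1.9-fold higher number from compound 3 to compound 4 (0.28 log units; within the scatter) for formyl(methyl)amino in place of isopropylamino on an aromatic carbon of the shared core. At this position, then, the exchange of one group for another of the same heavy-atom count, with the hydrogen-bond donor gone and a double bond outside the aromatic rings added, leaves the number within what repeated measurements of the same compound could give, and this holds for this one pair only. No measurement of any property of these two groups is at hand that would bear on this result.

Formyl(methyl)amino differs from isopropylamino in several features at once, so this pair cannot tell which feature, if any, matters at this position, and a group such as ethyl(methyl)amino, which also has no hydrogen-bond donor but has no carbonyl, would separate the two. From the compounds shown here alone, whether a much larger group on the same carbon, such as a longer chain like n-hexylamino or a ring like morpholine, would also stay this close to compound 3 remains open.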